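The source may report more compounds than this note shows. Statements on the series, on what has been measured and on what is new or still open speak of the compounds shown alone.

Compound 2 `OB1OCc2ccc(-n3cc(Sc4ccc(F)cc4)c4ccccc43)cc21` and compound 1 `OB1OCc2ccc(-n3cc(Sc4ccc(Cl)cc4)c4ccccc43)cc21` share one core and differ only in the way set out by chloro in place of fluoro on an aromatic carbon. In an ADME assay on L929 cells (Mus musculus) for cytotoxicity, read by resazurin assay, with a stated time of 72 h (a higher number here means a weaker inhibitor, a lower number a stronger inhibitor), compound 2 gives > 10 ug/mL, which is a limit of the assay. In this assay compound 1 gives > 10 ug/mL, also a limit. The step between them is therefore a step that the two limits leave unreadable from compound 2 to compound 1. Compound 3 `O=C(c1ccc(F)cc1)c1ccn(-c2ccc3c(c2)B(O)OC3)c1` carries a different core, and the difference between the two cores is not broken down here. In this assay compound 3 gives > 10 ug/mL, again a limit; this is the same limit noted as the limit of > 10 ug/mL in this assay, at which 3 of the 3 values shown sit. Compound 4 `O=C(c1ccc(Cl)cc1)c1ccn(-c2ccc3c(c2)B(O)OC3)c1` differs from compound 3 by chloro in place of fluoro on an aromatic carbon, the same change as that from compound 2 to compound 1. Since both limits leave the earlier step unreadable, compound 4 is expected to sit at the limit as well, so the estimated step is a step that the limit leaves unreadable from compound 3 to compound 4 and the estimate for compound 4 is 20 ug/mL, between 8 ug/mL and 50 ug/mL.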

Compound 4, half-maximal inhibitory concentration: > 10 ug/mL
Compound 4: only a limit was reported; the forecaster's own chance of this, stated with the estimate: 85%; the middle value is on the limit's open side.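

No step between compound 3 and compound 4 can be read in this assay, since each compound's result there is only a limit: the limit of > 10 ug/mL in this assay, at which 4 of the 4 values shown sit.

The compounds shown leave open whether chloro in place of fluoro changes the read-out of this assay on either core.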